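Swapping a methoxyphenyl for a fluorophenyl on the shared core

The source may hold more compounds than are shown below. What is called first, only, known or untested is meant among the compounds shown, and "the series" means these compounds.

Compound 2 `COc1ccccc1NC1=CC(=O)c2c(nc3n2[C@H]2OC[C@@H](O)[C@H]2OC3)C1=O` gives 6580 nM in a functional assay on MCF7 cells (Homo sapiens) for inhibition, read by sulforhodamine B assay (a higher number here means a weaker inhibitor, a lower number a stronger inhibitor), the highest of the two numbers reported here, since compound 1 `CCc1ccc(NC2=CC(=O)c3nc4n(c3C2=O)[C@H]2OC[C@@H](O)[C@H]2OC4)cc1` gives 960 nM. Compound 3 `CCOc1ccccc1NC1=CC(=O)c2nc3n(c2C1=O)[C@H]1OC[C@@H](O)[C@H]1OC3` reaches only a limit of this assay, > 4000 nM. That limit is the limit of > 4000 nM in this assay, at which 1 of the 3 values shown sits. Compound 4 `O=C1C(Nc2cccc(F)c2)=CC(=O)c2c1nc1n2[C@H]2OC[C@@H](O)[C@H]2OC1` differs from compound 2 in one place: 3-fluorophenyl in place of 2-methoxyphenyl on an amine nitrogen. For the measured compounds named here, no measured step swaps exactly these two groups. The nearest comparison is an at least 4.1-fold higher number from compound 1 to compound 3 (0.61 log units; beyond the scatter), where 2-ethoxyphenyl replaced 4-ethylphenyl and the number rose. Compound 2 with its 2-methoxyphenyl and compound 3 with its 2-ethoxyphenyl both sit at higher numbers than compound 1, so removing such a group and bringing in 3-fluorophenyl is expected to lower the number, though by how much is uncertain. For compound 4 the expected step is a 3.3-fold lower number from compound 2 to compound 4 (0.52 log units; beyond the scatter). Compound 4 is therefore estimated at 2000 nM in this assay, most likely between 700 nM and 6000 nM.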

Compound 4, half-maximal inhibitory concentration: > 4000 nM
Compound 4: a limit, no number; the forecaster's own chance of this, stated with the estimate: 15%; middle value at least 2.0-fold (0.30 log units) away from the limit.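

For the compounds shown here, compound 4 gives only a limit of the assay, not a number, so no step from compound 2 to compound 4 can be read: the limit of > 4000 nM in this assay, at which 2 of the 4 values shown sit. In this assay, the compounds shown leave open whether 3-fluorophenyl gives a higher or lower number than 2-methoxyphenyl on this amine nitrogen.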